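Chloro in place of fluoro: compound 3 to compound 4

A few compounds are considered here, and "the series" means these few. Any claim that something is new, unique, unknown or untested is made for them only; others in the source may bear on it.

Compound 1 `Nc1nc(NCCNc2ncc(-c3ncc[nH]3)c(-c3ccc(Cl)cc3)n2)ccc1[N+](=O)[O-]` gives > 0.5 h as a limit
Compound 2 `Nc1nc(NCCNc2ncc(-c3ncc[nH]3)c(-c3cc(F)ccc3Cl)n2)ccc1[N+](=O)[O-]` gives > 0.5 h as a limit
Compound 3 `Nc1nc(NCCNc2ncc(-c3ncc[nH]3)c(-c3ccc(Br)cc3F)n2)ccc1[N+](=O)[O-]` gives > 0.5 h as a limit

In an ADME assay on microsomes from liver (Rattus norvegicus) for metabolic stability (on this read-out higher numbers stand for a longer-lived compound and lower numbers for a shorter-lived compound), compound 3 gives > 0.5 h as a limit and not a number. The series offers only the limit of > 0.5 h in this assay, at which 3 of the 3 values shown sit, as its evidence. Compound 4 `Nc1nc(NCCNc2ncc(-c3ncc[nH]3)c(-c3ccc(Br)cc3Cl)n2)ccc1[N+](=O)[O-]` differs from compound 3 by chloro in place of fluoro on an aromatic carbon in one place: chloro in place of fluoro on an aromatic carbon. The steps a step that the two limits leave unreadable from compound 1 to compound 3 and a step that the two limits leave unreadable from compound 2 to compound 3 bear on it and neither has a readable size. So no step beyond the scatter is expected in this assay and no direction can be given. The expected step is a step that the limit leaves unreadable from compound 3 to compound 4 and stays within the scatter. Compound 4 is estimated at 0.6 h with an expected range from 0.35 h to 1 h and a report as a limit is likely.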

Compound 4, half-life: > 0.5 h
Compound 4: only a limit was reported; the forecaster's own chance of this, stated with the estimate: 80%; the middle value is on the limit's open side.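

Going by these compounds alone, compound 4, like compound 1, compound 2 and compound 3, gives only a limit in this assay, so no step among them can be read: the limit of > 0.5 h in this assay, at which 4 of the 4 values shown sit.

The compounds shown leave open the actual half-life of each compound, and so whether chloro in place of fluoro changes it.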